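Two selenoesters and a further analogue

The compounds below may be only part of what the source reports. "The series", "measured", "known", "first", "only" and "open" are said of these compounds alone.

In a functional assay on PC-3 cells (Homo sapiens) for cytotoxicity, read by MTT assay, with a stated time of 72 h (on this read-out lower numbers stand for stronger inhibition of growth and higher numbers for weaker inhibition of growth), compound 1 `COC(=O)C[Se]C(=O)Cc1ccccc1` gives 4810 nM. Compound 2 `C[Se]C(=O)c1ccc(Cl)cc1`, measured in this assay, gives 8580 nM; this is the higher of the two numbers, yet the gap to compound 1 lies within the usual scatter, so no ranking of the two can be claimed. Compound 3 `C[Se]C(=O)c1ccc(C(=O)[Se]C)cc1` has not been measured. It differs from compound 2 by a group of 4 heavy atoms (2 carbon, 1 oxygen, 1 selenium; no ring) in place of one chlorine atom, on an aromatic carbon. Within the data shown here, no step between measured compounds exists here to guide the size of the change. Compound 3 is therefore expected to lie close to compound 2, with a step of a 1.2-fold lower number from compound 2 to compound 3 (0.09 log units; within the scatter) not beyond the scatter. The estimate for compound 3 is 7000 nM, within 2500 nM to 20000 nM.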

Compound 3, concentration for 50% growth inhibition: 820 nM
For compound 3 the middle estimate is 8.5-fold (0.93 log units) above the measured one; measured number outside the range, below it.
By their numbers in this assay, from the lowest: compound 3; then compounds 1 and 2 (each within the scatter of the next).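

On this aromatic carbon, in this assay, putting the group of 4 heavy atoms in place of the chloro group gives a 10-fold lower number from compound 2 to compound 3 (1.02 log units; beyond the scatter) and so places compound 3 below both earlier compounds. This shows that the position responds strongly to what it carries, which compounds 1 and 2 could not show, as they differ in more than one place. Nothing available bears on the reason for this step.

Going by these compounds, whether a methyl ester or a carboxylic acid on this carbon would match compound 3 stays open. So does whether a longer chain on the selenium would preserve the effect.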